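The compounds below may be only part of what the source reports. "The series", "measured", "known", "first", "only" and "open" are said of these compounds alone.

Working notes on the series

Of the compounds shown here, three measured so far share the core and a 2-fluorophenyl amide: compound 1 `O=C(Nc1ccccc1F)c1cccc2[nH]c(-c3cccnc3)nc12`, compound 2 `COc1ccc(-c2nc3c(C(=O)Nc4ccccc4F)cccc3[nH]2)cc1OC` and compound 3 `COc1ccc(-c2nc3c(C(=O)Nc4ccccc4F)cccc3[nH]2)c(OC)c1OC`. In an ADME assay on Vero cells (Chlorocebus sabaeus) for cytotoxicity (on this read-out higher numbers stand for lower toxicity in this test and lower numbers for higher toxicity in this test), compound 1 gives 54.7 uM, compound 2 gives 24.5 uM and compound 3 gives 37.8 uM; compound 3 stands second highest of the three numbers, its gaps to both neighbours within the scatter. Within the data shown here, the only step between single-change neighbours, a 1.5-fold higher number from compound 2 to compound 3 (0.19 log units; within the scatter), concerns a methoxy group and is within the scatter. Compound 4 `COc1ccc(-c2nc3c(C(=O)Nc4cnc(Cl)cn4)cccc3[nH]2)c(OC)c1OC` differs from compound 3 by 5-chloropyrazin-2-yl in place of 2-fluorophenyl on an amide-type nitrogen. Among the measured compounds shown here, no measured step bears on the amide-type nitrogen substituent, so the existing data give no direction; a step not beyond the scatter is expected, a 1.1-fold lower number from compound 3 to compound 4 (0.03 log units; within the scatter). For compound 4 the expected value in this assay is 35 uM, with a range of 15 uM to 80 uM.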

Compound 4, half-maximal toxic concentration: 65.2 uM
Beside the measured number, compound 4's estimate is 1.9-fold (0.27 log units) below it; the range from low to high includes it.
By their numbers in this assay, from the lowest: compounds 2, 3, 1 and 4 (each within the scatter of the next, the first and the last beyond it).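

In this assay the amide-type nitrogen now has its first measured step, with 5-chloropyrazin-2-yl in place of 2-fluorophenyl giving a 1.7-fold higher number from compound 3 to compound 4 (0.24 log units; within the scatter). This position therefore tolerates a ring with 2 hetero atoms and 2 hydrogen-bond acceptors in place of a carbon-only ring without a step beyond the scatter in this read-out. Nothing available explains this result.

Open, as far as these compounds go, is how an aliphatic amine or a longer alkyl chain on the amide-type nitrogen would read. Also open, from the compounds shown here alone, is whether the same exchange gives a similar step in compound 1 and compound 2.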